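Moving the dichlorobenzyl ether onto the chloro-substituted core

The source may hold more compounds than are shown below. What is called first, only, known or untested is meant among the compounds shown, and "the series" means these compounds.

Three compounds share one core and differ at two sites. Compound 1 `Cc1ccc(NC(=S)NC(=O)c2ccc(OCc3ccc(C(F)(F)F)cc3)cc2)cc1-c1nc2ccccc2[nH]1` gives 6500 nM in a functional assay on MGC-803 cells (Homo sapiens) for inhibition, read by MTT assay, with a stated time of 48 h; a lower number here means a stronger inhibitor, a higher number a weaker inhibitor. Compound 2 `Cc1ccc(NC(=S)NC(=O)c2ccc(OCc3ccc(Cl)c(Cl)c3)cc2)cc1-c1nc2ccccc2[nH]1` gives 6390 nM in this assay, and the change a 1.0-fold lower number from compound 1 to compound 2 (0.01 log units; within the scatter) is a matter of 3,4-dichlorophenyl in place of 4-(trifluoromethyl)phenyl on a saturated chain carbon bound to an oxygen on an aromatic ring. Compound 3 `O=C(NC(=S)Nc1ccc(Cl)c(-c2nc3ccccc3[nH]2)c1)c1ccc(OCc2ccc(C(F)(F)F)cc2)cc1` gives 5330 nM in this assay; it carries chloro in place of methyl on an aromatic carbon, and the step of a 1.2-fold lower number from compound 1 to compound 3 (0.09 log units; within the scatter) is likewise small. Compound 3 therefore stands at the low end of the three numbers, but its gaps to compound 1 and to compound 2 both lie within the scatter, so no ranking among them can be claimed.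

Compound 4 `O=C(NC(=S)Nc1ccc(Cl)c(-c2nc3ccccc3[nH]2)c1)c1ccc(OCc2ccc(Cl)c(Cl)c2)cc1` has not yet been measured. It differs from compound 3 by 3,4-dichlorophenyl in place of 4-(trifluoromethyl)phenyl on a saturated chain carbon bound to an oxygen on an aromatic ring. For the measured compounds named here, the one measured step that bears on this exchange is a 1.0-fold lower number from compound 1 to compound 2 (0.01 log units; within the scatter), made on the methyl-bearing core, and it produced essentially no movement. On that basis compound 4 is expected to show a 1.0-fold lower number from compound 3 to compound 4 (0.01 log units; within the scatter), with no shift beyond the scatter in either direction. The estimate for compound 4 in this assay is 5200 nM, within a range from 2600 nM to 10400 nM.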

Compound 4, half-maximal inhibitory concentration: 5170 nM
Estimate against measurement, compound 4: 1.0-fold (0.00 log units) above; the measured number falls inside the stated range.
By their numbers in this assay, from the lowest: compounds 4, 3, 2 and 1 (each within the scatter of the next).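

The exchange of 4-(trifluoromethyl)phenyl for 3,4-dichlorophenyl on a saturated chain carbon bound to an oxygen on an aromatic ring has now been read on a second core, and in this assay it gives a 1.0-fold lower number from compound 3 to compound 4 (0.01 log units; within the scatter), which shows that the flat result on the methyl-bearing core is not confined to that core: the same change on two cores in this assay, a 1.0-fold lower number (0.01 log units; within the scatter) from compound 1 to compound 2 and a 1.0-fold lower number (0.01 log units; within the scatter) from compound 3 to compound 4, 1.0-fold (0.01 log units) apart, within the scatter of two such steps The chloro in place of methyl on an aromatic carbon, earlier read only with 4-(trifluoromethyl)phenyl in the molecule, now also has a reading with 3,4-dichlorophenyl, a 1.2-fold lower number from compound 2 to compound 4 (0.09 log units; within the scatter), and it too stays small: the same change on two cores in this assay, a 1.2-fold lower number (0.09 log units; within the scatter) from compound 1 to compound 3 and a 1.2-fold lower number (0.09 log units; within the scatter) from compound 2 to compound 4, 1.0-fold (0.01 log units) apart, within the scatter of two such steps Across these four compounds, neither exchange shifts the number beyond the scatter on either core, and neither step differs between its two cores by more than the scatter of two such steps.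

The compounds shown leave open whether these two sites respond to anything at all, as the two exchanges tested here give no separation. An amine or a carboxylic acid on the benzyl ring, or a longer chain in place of the benzyl group, might still shift the number, and the same question stands for a methoxy group in place of the chloro or methyl.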